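The source may report more compounds than this note shows. Statements on the series, on what has been measured and on what is new or still open speak of the compounds shown alone.

Measured compounds:
Compound 1, `COc1cc(-c2nn(-c3cccc(NC(=O)c4cccc(C(F)(F)F)c4)c3)cc2-c2ccncc2)ccc1Cl` — 1890 nM in a functional assay on ACHN cells (Homo sapiens) for inhibition, read by sulforhodamine B assay, with a stated time of 48 h; on this read-out lower numbers stand for stronger inhibition of growth and higher numbers for weaker inhibition of growth
Compound 2, `COc1cc(-c2nn(-c3cccc(NC(=O)c4ccc(Cl)c(C(F)(F)F)c4)c3)cc2-c2ccncc2)ccc1Cl` — 2730 nM in this assay

Among the compounds with values here, compound 2 carries the higher of the two numbers, but the only step between them, a 1.4-fold higher number from compound 1 to compound 2 (0.16 log units; within the scatter), is too small to tell the two compounds apart.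

Compound 3, `COc1cc(-c2nn(-c3cccc(NC(=O)c4ccccc4)c3)cc2-c2ccncc2)ccc1Cl`, has not yet been measured in this assay. It differs from compound 2 by one change: phenyl in place of 4-chloro-3-(trifluoromethyl)phenyl on a carbonyl carbon. Within the data shown here, the one measured step that touches this part of the molecule is a 1.4-fold higher number from compound 1 to compound 2 (0.16 log units; within the scatter), which covers only the chloro and stayed within the scatter. Among the measured compounds shown here, no measured compound lacks the trifluoromethyl, so its removal is unknown ground. The expectation is therefore a step of a 1.2-fold lower number from compound 2 to compound 3 (0.09 log units; within the scatter), not clearly beyond the scatter in either direction. Compound 3 is estimated at 2200 nM, expected between 800 nM and 6000 nM.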

Compound 3, concentration for 50% growth inhibition: 754 nM
Beside the measured number, compound 3's estimate is 2.9-fold (0.47 log units) above it; measured number below the stated range.
By their numbers in this assay, from the lowest: compound 3; then compounds 1 and 2 (each within the scatter of the next).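

In this assay the plain phenyl on the carbonyl carbon gives the lowest number of the three compounds, with a 3.6-fold lower number from compound 2 to compound 3 (0.56 log units; beyond the scatter) and, for the loss of the trifluoromethyl alone, a 2.5-fold lower number from compound 1 to compound 3 (0.40 log units; beyond the scatter). Within the data shown here, until now only the chloro had been varied here, and that change stayed within the scatter, so this is the first sign that the number responds to what sits on this carbonyl carbon, and that a bare phenyl does better here than either substituted one. No measurement is available that would explain this difference.

Going by these compounds, it remains open whether any group on this phenyl could lower the number further, for example a methyl, a fluorine, an amine or a carboxylic acid. Also open, on these data alone, is how a saturated group such as cyclohexyl would behave in place of the phenyl.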